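A few compounds are considered here, and "the series" means these few. Any claim that something is new, unique, unknown or untested is made for them only; others in the source may bear on it.

Compound 1 `CC(C)(C)c1cc(NC(=O)Nc2cc(C(F)(F)F)cc(C(F)(F)F)c2)n(-c2ccc(F)cc2)n1`: -0.6 degrees C
Compound 2 `CC(C)(C)c1cc(NC(=O)Nc2cc(C(F)(F)F)cc(C(F)(F)F)c2)n(C(C)(C)C)n1`: -0.7 degrees C
Compound 3 `CC(C)(C)c1cc(NC(=O)Nc2cc(F)cc(F)c2)n(-c2ccc(F)cc2)n1`: 1.7 degrees C

Three ureas were measured in an assay on isolated protein for inhibition of serine/threonine-protein kinase 10 (Homo sapiens), read by thermal shift assay, tested at 10 uM; on this read-out lower numbers stand for weaker stabilisation of the target and higher numbers for stronger stabilisation of the target against heat. Compound 1 gives -0.6 degrees C in this assay, and compound 2 gives -0.7 degrees C. The two differ in one place, (tert-butyl in place of 4-fluorophenyl on an aromatic nitrogen), and the resulting step is a number 0.10 degrees C lower from compound 1 to compound 2 (within the scatter), so the two values are indistinguishable. Compound 3 gives 1.7 degrees C, the highest of the three; its gap to compound 1 and to compound 2 lies beyond the scatter in both cases. How compound 3 differs from compound 1 is not broken down here.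

Compound 4 `CC(C)(C)c1cc(NC(=O)Nc2cc(F)cc(F)c2)n(C(C)(C)C)n1` has not been measured. It relates to compound 3 exactly as compound 2 relates to compound 1: the difference is tert-butyl in place of 4-fluorophenyl on an aromatic nitrogen, and the place description is the same word for word, so this is the same change made a second time. The earlier instance left the value essentially unchanged, as shown by a number 0.10 degrees C lower from compound 1 to compound 2 (within the scatter). Among the measured compounds shown here, on that basis compound 4 is expected to stay close to compound 3, with an expected step of a number 0.10 degrees C lower from compound 3 to compound 4 (within the scatter) in this assay, the expectation resting on the one prior step only because a number 0.10 degrees C lower from compound 1 to compound 2 (within the scatter) is the sole measured instance of this change. The estimate for compound 4 in this assay is 1.6 degrees C, expected to fall between 0.3 degrees C and 2.9 degrees C.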

Compound 4, shift of the target's melting temperature: -0.2 degrees C
The estimate for compound 4 lay 1.8 degrees C above the measured number; the whole stated range lies above it.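

In this assay, the effect of putting tert-butyl in place of 4-fluorophenyl on an aromatic nitrogen did not carry over from one core to the other: the same change on two cores in this assay, a number 0.10 degrees C lower (within the scatter) from compound 1 to compound 2 and a number 1.9 degrees C lower (beyond the scatter) from compound 3 to compound 4, 1.8 degrees C apart, beyond the scatter of two such steps. On the core of compound 3 the change lowers the stabilisation of the target, a number 1.9 degrees C lower from compound 3 to compound 4 (beyond the scatter), so the flat result on the core of compound 1 is no safe guide to what this change does elsewhere in the series. These two instances show only that the outcome depends on the core; they do not show which feature of the cores sets the difference, nor what the change would do on a third core.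

The compounds shown leave open how other groups on the same aromatic nitrogen would read, such as a methyl, an unsubstituted phenyl or a chain ending in an amine, and so whether 4-fluorophenyl itself matters on the core of compound 3. They also leave open whether the urea's aromatic ring would tolerate other substituents in place of fluorine or trifluoromethyl, such as a nitrile, a methoxy group or a carboxylic acid, and how the change at the nitrogen would behave on such cores.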